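Aminopyridine series: solubility notes toward compound 4

The compounds below may be only part of what the source reports. "The series", "measured", "known", "first", "only" and "open" are said of these compounds alone.

Measured compounds:
compound 1 `COc1ccc(-c2cc(-c3ccc(S(=O)(=O)NC4CC4)cc3)cnc2N)cn1`, 6.3 ug/mL
compound 2 `COc1ccc(-c2cc(-c3ccc(S(C)(=O)=O)cc3C(F)(F)F)cnc2N)cn1`, 12.5 ug/mL
compound 3 `COc1ccc(-c2cc(-c3ccc4cnn(C)c4c3)cnc2N)cn1`, 6.3 ug/mL

Of the compounds shown here, three of the shared core have been read in a physicochemical assay for solubility, read by nephelometry, in phosphate buffer, measured as kinetic solubility, at pH 6.5; a higher number here means a more soluble compound, a lower number a less soluble compound. Compound 1 gives 6.3 ug/mL, and compound 3 gives 6.3 ug/mL, the two standing level at the digits shown; together they are the lowest of the three numbers. Compound 2 gives 12.5 ug/mL, the highest number, but its gap to compound 1 stays within the scatter, so no order among the three is established.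

Compound 4 `COc1ccc(-c2cc(-c3ccc(C(N)=O)cc3)cnc2N)cn1` is not yet measured. It differs from compound 1 in one place: carbamoyl in place of cyclopropylsulfamoyl on an aromatic carbon. Among the measured compounds shown here, no measured pair in the set makes this same change, so the size of the step must be guessed from the set as a whole, which spans a narrow band of values. A small upward step in this assay is expected, probably not beyond the scatter; the expected move is a 1.6-fold higher number from compound 1 to compound 4 (0.20 log units; within the scatter). Compound 4 is estimated at 10 ug/mL, with a range from 3.5 ug/mL to 30 ug/mL.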

Compound 4, solubility: 12.5 ug/mL
The estimate for compound 4 lay 1.3-fold (0.10 log units) below the measured number, and the stated range covers the measured number.
By their numbers in this assay, from the lowest: compounds 1, 3, 2 and 4 (each within the scatter of the next).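

In this assay, among the compounds shown here, the exchange of cyclopropylsulfamoyl for carbamoyl on an aromatic carbon, para to a large group, gives a 2.0-fold higher number from compound 1 to compound 4 (0.30 log units; within the scatter) and provides the first step in the set that can be read at a single place. The exchange removes 7 heavy atoms, including the three-membered ring, and brings in 3 heavy atoms with no ring, yet no difference beyond the scatter is established between compound 1 and compound 4. At this position, therefore, neither the sulfamoyl group nor its cyclopropyl part is shown to be needed to keep the reading in the band of the set, and nothing at hand bears on what sets the level of these numbers.

On these data alone, it remains open whether any group at this position can move the reading beyond the scatter, as a carboxylic acid or a dimethylamino group on the same aromatic carbon might or might not. For the compounds shown here, with only one single-place step available, it is also open whether the size of this step would hold on any other substitution of the shared core.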